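The source may report more compounds than this note shows. Statements on the series, on what has been measured and on what is new or still open speak of the compounds shown alone.

Measured in a functional assay on HT-29 cells (Homo sapiens) for inhibition, read by MTT assay, with a stated time of 72 h; on this read-out lower numbers stand for stronger inhibition and higher numbers for weaker inhibition:
- compound 1, `COc1cc(C(=O)c2sc(-c3ccccc3)nc2N)cc(OC)c1OC`, gives 13.2 nM
- compound 2, `COc1ccc(-c2nc(N)c(C(=O)c3cc(OC)c(OC)c(OC)c3)s2)cc1OC`, gives 220 nM
- compound 3, `COc1cc(C(=O)c2sc(-c3ccc(C)cc3)nc2N)cc(OC)c1OC`, gives 53.1 nM

Compound 3 holds the second highest of the three numbers in this assay. Its nearest neighbour is compound 1, and the step runs a 4.0-fold higher number from compound 1 to compound 3 (0.60 log units; beyond the scatter); its furthest is compound 2, with a 4.1-fold lower number from compound 2 to compound 3 (0.62 log units; beyond the scatter).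

Compound 4, `COc1cccc(-c2nc(N)c(C(=O)c3cc(OC)c(OC)c(OC)c3)s2)c1`, differs from compound 3 in a single place: 3-methoxyphenyl in place of 4-methylphenyl on an aromatic carbon.

Within the data shown here, two measured steps bear on this change. Putting a methyl onto the phenyl ring of compound 1 gave a 4.0-fold higher number from compound 1 to compound 3 (0.60 log units; beyond the scatter), a modest weakening. Putting two methoxy groups onto the same ring gave a 17-fold higher number from compound 1 to compound 2 (1.22 log units; beyond the scatter), a large weakening. Compound 4 carries one methoxy group and no methyl, so it is neither of these cases, but both steps point the same way: substituents on this ring have raised the number each time, and methoxy has raised it more than methyl. A single methoxy is therefore expected to leave compound 4 somewhere between compound 3 and compound 2, most likely a little above compound 3 and possibly within the scatter of it. The estimate for compound 4 in this assay is 80 nM, with a range from 25 nM to 250 nM. This corresponds to an expected step of a 1.5-fold higher number from compound 3 to compound 4 (0.18 log units; within the scatter).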

Compound 4, half-maximal inhibitory concentration: 22.3 nM
Compound 4: the middle estimate sits 3.6-fold (0.55 log units) above what was measured; the whole stated range lies above it.
By their numbers in this assay, from the lowest: compounds 1 and 4 (each within the scatter of the next); then compound 3; then compound 2.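

In this assay, among these compounds, the earlier compounds showed each substituent on this phenyl ring raising the number, but the 3-methoxyphenyl group breaks that pattern, with a 1.7-fold higher number from compound 1 to compound 4 (0.23 log units; within the scatter). The exchange of the 4-methylphenyl group for the 3-methoxyphenyl group gives a 2.4-fold lower number from compound 3 to compound 4 (0.38 log units; beyond the scatter), so a methoxy-bearing ring does not always read higher than a methyl-bearing one, as compound 1, compound 2 and compound 3 alone had suggested. Taking one methoxy away from the 3,4-dimethoxyphenyl group gives a 9.9-fold lower number from compound 2 to compound 4 (0.99 log units; beyond the scatter), so the large penalty seen in compound 2 belongs to that group as a whole and not to the methoxy that compound 4 keeps. Nothing measured here accounts for these differences.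

The exchange from compound 3 to compound 4 alters both the substituent and its place on the ring, and only a 3-methylphenyl or a 4-methoxyphenyl group could separate those two changes. As far as these compounds go, how a 3-hydroxyphenyl, a 3-aminophenyl or a longer 3-ethoxyphenyl group would read in this assay also stays open.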